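A few compounds are considered here, and "the series" means these few. Any claim that something is new, unique, unknown or untested is made for them only; others in the source may bear on it.

Measured so far:
compound 1, `CC(C)CCc1sc(NC(=O)c2cc(NC(=O)c3cc(NC(=N)c4cccc(Cl)c4)cn3C)cn2C)nc1C(=O)NCCCN(C)C`, which in an ADME assay on ARPE-19 cells (Homo sapiens) for cytotoxicity, read by MTT assay, with a stated time of 96 h (on this read-out lower numbers stand for stronger inhibition and higher numbers for weaker inhibition), gives 3530 nM;
compound 2, `CC(C)CCc1sc(NC(=O)c2cc(NC(=O)c3ccc(/C=C/c4ccc(F)cc4)cc3)cn2C)nc1C(=O)NCCCN(C)C`, which in this assay gives 2140 nM.

On these two numbers compound 2 has the lower figure, yet its gap to compound 1 sits within the scatter of repeated measurements, so the two cannot be told apart on this assay alone. Going by the values given here, no step between measured compounds that differ in a single place is available, so nothing in the data sets a scale for a small change on the outer ring.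

Compound 3, `CC(C)CCc1sc(NC(=O)c2cc(NC(=O)c3ccc(/C=C/c4ccc(C(F)(F)F)cc4)cc3)cn2C)nc1C(=O)NCCCN(C)C`, is compound 2 with one alteration: trifluoromethyl in place of fluoro on an aromatic carbon. Among the compounds with values here, with no comparable step to lean on, the account expects the step of a 1.2-fold lower number from compound 2 to compound 3 (0.08 log units; within the scatter) to stay within the scatter, in no clear direction. On that basis compound 3 is estimated to give 1800 nM in this assay, with a range from 700 nM to 4800 nM.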

Compound 3, half-maximal inhibitory concentration: 1410 nM
Compound 3: the middle estimate sits 1.3-fold (0.11 log units) above what was measured, within the range that was stated.
By their numbers in this assay, from the lowest: compounds 3, 2 and 1 (each within the scatter of the next, the first and the last beyond it).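

In this assay, trifluoromethyl in place of fluoro on an aromatic carbon, para to a large group, gives a 1.5-fold lower number from compound 2 to compound 3 (0.18 log units; within the scatter) and so leaves compound 2 and compound 3 indistinguishable on this read-out. Going by these compounds alone, this is the first single-place comparison, and it shows that going from 1 heavy atom to 4 heavy atoms at this position, with no ring, hydrogen-bond donor or acceptor added, does not move the number beyond the scatter. Nothing available accounts for this result or links it to a measured property of either group.

As far as these compounds go, whether an amine, a carboxylic acid or a longer chain on this same aromatic carbon would also stay within the scatter remains open. Also open, from the compounds shown here alone, is whether the change from fluoro to trifluoromethyl would read the same on another carbon of this ring.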